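A few compounds are considered here, and "the series" means these few. Any claim that something is new, unique, unknown or untested is made for them only; others in the source may bear on it.

Compound 1 `OC[C@H]1O[C@@H](n2cnc3c(NCc4cccc(F)c4)ncnc32)[C@H](O)[C@@H]1O`: 15300 nM
Compound 2 `Cc1ccc(CNc2ncnc3c2ncn3[C@@H]2O[C@H](CO)[C@@H](O)[C@H]2O)cc1`: > 166000 nM
Compound 3 `OC[C@H]1O[C@@H](n2cnc3c(NCc4ccc(F)cc4Cl)ncnc32)[C@H](O)[C@@H]1O`: > 166000 nM

All three were tested in a functional assay on MCF cells (Homo sapiens) for antiproliferative activity, with a stated time of 72 h; a higher number here means a weaker inhibitor, a lower number a stronger inhibitor. Compound 3 gives no number there, only a limit: the limit of > 166000 nM in this assay, at which 2 of the 3 values shown sit.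

Compound 4 `OC[C@H]1O[C@@H](n2cnc3c(NCc4cc(O)cc(O)c4)ncnc32)[C@H](O)[C@@H]1O` differs from compound 3 by 3,5-dihydroxyphenyl in place of 2-chloro-4-fluorophenyl on a saturated chain carbon bound to a nitrogen on an aromatic ring, with 3,5-dihydroxyphenyl in place of 2-chloro-4-fluorophenyl. Two measured steps change the same group, and both are large: an at least 10-fold higher number from compound 1 to compound 2 (1.03 log units; beyond the scatter) and an at least 10-fold higher number from compound 1 to compound 3 (1.03 log units; beyond the scatter). The third, a step that the two limits leave unreadable from compound 2 to compound 3, cannot be sized. These steps show that this group can matter, but not how the new one will behave. Since compound 3 has only a limit, a small move towards a lower number is expected, though compound 4 may well stay at the limit. The expected step runs an at least 1.8-fold lower number from compound 3 to compound 4 (0.26 log units; that floor lies within the scatter). Compound 4 is estimated at 90000 nM, with an expected range of 20000 nM to 200000 nM.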

Compound 4, half-maximal inhibitory concentration: > 166000 nM
Compound 4: no number, only a limit (the forecaster's own chance of this, stated with the estimate: 50%); middle value at least 1.8-fold (0.26 log units) from the limit.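

The 3,5-dihydroxyphenyl group carries hydrogen-bond donors that the 2-chloro-4-fluorophenyl it replaces lacks, yet this change also gives an at least 10-fold higher number from compound 1 to compound 4 (1.03 log units; beyond the scatter). On this saturated chain carbon bound to a nitrogen on an aromatic ring, only the 3-fluorophenyl of compound 1 gives a readable value in this assay: the limit of > 166000 nM in this assay, at which 3 of the 4 values shown sit. The steps from compound 3 and from compound 2 to compound 4 join two limits and cannot be read.

On these data alone, it remains open how far apart the compounds at the limit truly lie. As far as these compounds go, it is also open whether a plain phenyl or a pyridyl ring would match the 3-fluorophenyl.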